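Methoxy in Place of Hydrogen on the Phenyl Group

A few compounds are considered here, and "the series" means these few. Any claim that something is new, unique, unknown or untested is made for them only; others in the source may bear on it.

Compound 1 `Brc1cn2ccnc2c(-c2ccc3ncn(C4CCCCC4)c3c2)n1` gives 15.2% in a functional assay on LOX IMVI cells (Homo sapiens) for inhibition, read by sulforhodamine B assay, with a stated time of 48 h, tested at 10 uM; a lower number here means less inhibition, a higher number more inhibition at the concentration tested (going by the name of the read-out).
Compound 2 `c1ccc(-c2cn3ccnc3c(-c3ccc4ncn(C5CCCCC5)c4c3)n2)cc1` gives 39.6% in this assay.

Compound 2 stands highest of the two numbers, and its nearest neighbour is compound 1. For the measured compounds named here, the only measured step, a number 24.4 percentage points higher from compound 1 to compound 2 (beyond the scatter), came from phenyl in place of bromo on an aromatic carbon, and it lay beyond the scatter while remaining modest in size.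

Compound 3 `COc1ccc(-c2cn3ccnc3c(-c3ccc4ncn(C5CCCCC5)c4c3)n2)cc1` differs from compound 2 by methoxy in place of hydrogen on an aromatic carbon. Going by the values given here, no measured step bears directly on this change: the one step known concerns a different group at a different place, and it says nothing about what a methoxy group added to the phenyl ring does here. With no guide from the data, compound 3 is expected to differ from compound 2 by a number 2.4 percentage points higher from compound 2 to compound 3 (within the scatter), a step within the usual scatter. Compound 3 is therefore estimated at 42%, with a range from 22% to 62%.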

Compound 3, a percentage reported as inhibition, at one concentration (the size of the read-out at that concentration, not a potency): 69.6%
For compound 3 the middle estimate is 27.6 percentage points below the measured one; measured number above the stated range.
By their numbers in this assay, from the lowest: compound 1; then compound 2; then compound 3.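

In this assay, the phenyl ring of compound 2 proves open to further gain: methoxy in place of hydrogen, para to a large group, gives a number 30 percentage points higher from compound 2 to compound 3 (beyond the scatter). Taken as a single change, 4-methoxyphenyl in place of bromo gives a number 54.4 percentage points higher from compound 1 to compound 3 (beyond the scatter), a large step, so the group at this place on the core can shift the read-out much further than the phenyl group alone showed. Nothing available explains why the methoxy group has this effect.

The compounds shown leave open whether this rise is particular to methoxy or would also appear with another group at the same place, such as an amine, a hydroxyl or a fluorine. They also do not show what methoxy would do on a different carbon of the phenyl ring.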